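Replacing methoxy with (4-methoxyphenyl)amino on compound 1

The compounds below may be only part of what the source reports. "The series", "measured", "known", "first", "only" and "open" are said of these compounds alone.

compound 1 `C=C[C@@](C)(/C=C/c1ccc(OC)cc1)CCC=C(C)C` gives > 52000 nM as a limit
compound 2 `C=C[C@@](C)(/C=C/c1ccc(O)cc1)CCC=O` gives > 52000 nM as a limit
compound 3 `C=C[C@@](C)(/C=C/c1ccc(O)c(/C=C/c2ccc(F)cc2)c1)CCC=C(C)C` gives > 52000 nM as a limit

In a functional assay on HepG2 cells (Homo sapiens) for cytotoxicity, with a stated time of 72 h (a lower number here means that less compound is needed, a higher number that more compound is needed for the effect), compound 1 has no number, only the limit > 52000 nM as its reading. Going by the values given here, the set offers the limit of > 52000 nM in this assay, at which 3 of the 3 values shown sit, and no measured step. Compound 4 `C=C[C@@](C)(/C=C/c1ccc(Nc2ccc(OC)cc2)cc1)CCC=C(C)C` has not been measured. It carries (4-methoxyphenyl)amino in place of methoxy on an aromatic carbon and this is the change followed here. Among the compounds with values here, with no step to guide the expectation, a small move in this assay towards less compound needed is expected, and the reading may well stay at the limit. The estimated change is an at least 1.3-fold lower number from compound 1 to compound 4 (0.13 log units; that floor lies within the scatter) as a modest step. Compound 4 is expected near 38000 nM with an estimated range of 14000 nM to 52000 nM for its value.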

Compound 4, half-maximal effective concentration: > 52000 nM
Compound 4 was reported as a limit (the forecaster's own chance of this, stated with the estimate: 60%); middle value at least 1.3-fold (0.13 log units) from the limit.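

Compound 1 and compound 4 both stand only as limits in this assay, so no step can be read between them: the limit of > 52000 nM in this assay, at which 4 of the 4 values shown sit.

The compounds shown leave open whether (4-methoxyphenyl)amino in place of methoxy moves the reading at all.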